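A few compounds are considered here, and "the series" means these few. Any claim that something is new, unique, unknown or untested is made for them only; others in the source may bear on it.

Compound 1 `CC(Oc1ccccc1-c1ccncc1)C1=NCCN1`: 2690 nM
Compound 2 `CC(Oc1ccccc1-c1cccs1)C1=NCCN1`: 214 nM
Compound 3 `CC(Oc1ccccc1-c1ccccn1)C1=NCCN1`: 3310 nM

All three share one core and differ only in the aromatic group attached to it. In an assay on CHO cells for displacement of a labelled ligand from Alpha-2B adrenergic receptor (Homo sapiens) (a higher number here means a weaker inhibitor, a lower number a stronger inhibitor), compound 3 gives the highest of the three numbers; compound 1 sits close, with a 1.2-fold higher number from compound 1 to compound 3 (0.09 log units; within the scatter) falling within the scatter, while compound 2 lies far lower, as a 15-fold higher number from compound 2 to compound 3 (1.19 log units; beyond the scatter) shows. The step to compound 4 `CC(Oc1ccccc1-c1ccc(O)cc1)C1=NCCN1` is 4-hydroxyphenyl in place of pyridin-2-yl on an aromatic carbon. Among the compounds with values here, no measured step brings in a carbon-only ring, but both pyridyl groups gave high numbers and the single thiophen-2-yl gave the lowest, as a 13-fold lower number from compound 1 to compound 2 (1.10 log units; beyond the scatter) shows. A drop in the number is therefore expected, though the hydroxyl has no precedent among these compounds, so the range stays wide. Compound 4 is estimated at 700 nM, between 150 nM and 3500 nM, an expected 4.7-fold lower number from compound 3 to compound 4 (0.67 log units; beyond the scatter).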

Compound 4, inhibition constant: 813 nM
For compound 4 the middle estimate is 1.2-fold (0.06 log units) below the measured one; the measured number falls inside the stated range.
By their numbers in this assay, from the lowest: compound 2; then compound 4; then compounds 1 and 3 (each within the scatter of the next).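

In this assay, with a 4.1-fold lower number from compound 3 to compound 4 (0.61 log units; beyond the scatter) and a 3.3-fold lower number from compound 1 to compound 4 (0.52 log units; beyond the scatter) as the two steps, 4-hydroxyphenyl, the only ring of carbon only here, gives a lower number than either pyridyl group. It does not match thiophen-2-yl, since a 3.8-fold higher number from compound 2 to compound 4 (0.58 log units; beyond the scatter) also lies beyond the scatter, so a six-membered ring is not ruled out at this position, though the five-membered thiophen-2-yl still gives the lowest number. No evidence is available to explain these differences.

Whether the drop comes from the ring of carbon only or from its hydroxyl stays open, as the compounds shown include no plain phenyl. A methoxy or an amine in place of the hydroxyl would also help separate the two.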